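Working notes on the cytotoxicity limits, compound 3 to compound 4

The compounds below may be only part of what the source reports. "The series", "measured", "known", "first", "only" and "open" are said of these compounds alone.

Measured so far:
compound 1 `NC(=O)/C=C/[C@H]1C[C@@H](O)[C@@H](O)C1` — in an ADME assay on S2 cells (Drosophila melanogaster) for cytotoxicity, read by MTT assay (a higher number here means that more compound is needed for the effect, a lower number that less compound is needed), compound 1 gives only the assay limit > 250000 nM.
compound 2 `O=C(/C=C/[C@H]1C[C@@H](O)[C@@H](O)C1)NC1CC1` — in this assay compound 2 also gives only a limit, > 250000 nM.
compound 3 `Cc1ccc(NC(=O)/C=C/[C@H]2C[C@@H](O)[C@@H](O)C2)cc1` — in this assay compound 3 gives only a limit, > 190000 nM.

Among the compounds with values here, compound 3 thus sits at the limit of > 190000 nM in this assay, at which 1 of the 3 values shown sits, the other two at the limit of > 250000 nM in this assay, at which 2 of the 3 values shown sit; no compound has a readable number. Within the data shown here, the single measured step, a step that the two limits leave unreadable from compound 1 to compound 2, runs between two limits and is not readable. Compound 4 `CN(C)c1ccc(NC(=O)/C=C/[C@H]2C[C@@H](O)[C@@H](O)C2)cc1` differs from compound 3 by dimethylamino in place of methyl on an aromatic carbon. Among the measured compounds shown here, no measured step bears on this change, so the expected step that the limit leaves unreadable from compound 3 to compound 4 is none beyond the scatter. Compound 4 is therefore estimated at 250000 nM, range 100000 nM to 600000 nM, most likely reported again as a limit.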

Compound 4, half-maximal effective concentration: > 170000 nM
Compound 4: a limit, no number; the forecaster's own chance of this, stated with the estimate: 85%; the middle value lies beyond the limit too.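

Compound 3 and compound 4 both stand only as limits, so no step can be read between them. The compounds shown leave open whether any compound in the series reaches a readable number in this assay.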